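Benzimidazole chalcone series: amide to sulfonamide on the anilide nitrogen

This account rests on a few compounds, and the source may have more. Where it says the series, first, only, none or still open, it means among the compounds named here.

Working notes on two measured compounds and one awaiting measurement. Compound 1 `Cc1ccc(C(=O)Nc2cccc(/C=C/C(=O)c3nc4ccccc4[nH]3)c2)cc1` in a functional assay on HCT-116 cells (Homo sapiens) for antiproliferative activity, read by MTT assay, with a stated time of 48 h (a lower number here means a stronger inhibitor, a higher number a weaker inhibitor), gives 1660 nM. Compound 2 `Cc1cc(C)cc(C(=O)Nc2cccc(/C=C/C(=O)c3nc4ccccc4[nH]3)c2)c1` in this assay gives 1550 nM; the step of a 1.1-fold lower number from compound 1 to compound 2 (0.03 log units; within the scatter) leaves the two within the scatter of each other, so neither can be set apart from the other. Compound 3 `O=C(/C=C/c1cccc(NS(=O)(=O)c2ccccc2Cl)c1)c1nc2ccccc2[nH]1` carries (2-chlorophenyl)sulfonyl in place of (3,5-dimethylphenyl)carbonyl on a nitrogen on an aromatic ring. Within the data shown here, the only measured step, from compound 1 to compound 2, concerns a change of methyl pattern on the phenyl of the carbonyl group and says nothing about exchanging the carbonyl link for a sulfonyl one or about a chlorine on that ring; no measured step bears on this change. The expected step of a 1.3-fold higher number from compound 2 to compound 3 (0.11 log units; within the scatter) is therefore set near no change, with a wide band in both directions. Compound 3 is estimated at 2000 nM in this assay, with a range from 500 nM to 8000 nM.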

Compound 3, half-maximal inhibitory concentration: 987 nM
The estimate for compound 3 lay 2.0-fold (0.31 log units) above the measured number; the range from low to high includes it.
By their numbers in this assay, from the lowest: compounds 3, 2 and 1 (each within the scatter of the next).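

At the position on a nitrogen on an aromatic ring, compound 3 shows that the link itself can be exchanged, not only the methyl pattern on the phenyl: a 1.6-fold lower number from compound 2 to compound 3 (0.20 log units; within the scatter) and a 1.7-fold lower number from compound 1 to compound 3 (0.23 log units; within the scatter) are both read in this assay and leave the three compounds unseparated. The (2-chlorophenyl)sulfonyl group therefore takes the place of both carbonyl groups here without a step beyond the scatter, so this change gives no measurable gain or loss in this series. Nothing on hand offers an explanation for where compound 3 lands.

Going by these compounds, the sulfonyl link and the chlorine enter together, so what each contributes alone stays open. Also open, on these data alone, is how a methylsulfonyl group, or a carboxylic acid on the phenyl ring, would read on this nitrogen.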